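This account rests on a few compounds, and the source may have more. Where it says the series, first, only, none or still open, it means among the compounds named here.

- compound 1 `Cc1ccc(S/C(=C/c2c[nH]c3ccccc23)C(=O)c2ccc(Br)cc2)cc1`: 10000 nM
- compound 2 `O=C(/C(=C\c1csc([N+](=O)[O-])c1)S(=O)(=O)c1ccc(Br)cc1)c1ccc(Br)cc1`: 1000 nM
- compound 3 `COc1cc(OC)c(/C=C(/SCc2ccc(Cl)c(Cl)c2)C(=O)c2ccc(Cl)cc2)c(OC)c1`: 10000 nM

These three compounds were tested in a functional assay on DU-145 cells (Homo sapiens) for inhibition, read by trypan blue exclusion, with a stated time of 96 h; a higher number here means a weaker inhibitor of growth, a lower number a stronger inhibitor of growth. Compound 2, at 1000 nM, has the lowest number of the three and is therefore the strongest inhibitor of growth in the set. Compound 1 and compound 3 both lie above it by more than the usual scatter.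

Compound 4 `COc1cccc(OC)c1/C=C(\C(=O)c1ccc(Br)cc1)S(=O)(=O)c1ccc(Br)cc1` has not yet been measured. It keeps the rest of compound 2 but carries 2,6-dimethoxyphenyl in place of 5-nitrothiophen-3-yl on a double-bonded chain carbon bound to a double-bonded chain carbon.

Among the measured compounds shown here, no pair of measured compounds differs in only one place, so the data cannot show how much a single swap matters in this assay. The estimate therefore stays close to the value of compound 2, 1000 nM, and its range is wide. The expected change is a 1.5-fold higher number from compound 2 to compound 4 (0.18 log units; within the scatter), a small move toward a higher number that stays within the scatter. For compound 4, the estimated value is 1500 nM, with an expected range of 300 nM to 8000 nM.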

Compound 4, concentration for 50% growth inhibition: 10000 nM
Compound 4: middle estimate off by 6.7-fold (0.82 log units), on the low side; the whole stated range lies below it.
By their numbers in this assay, from the lowest: compound 2; then compounds 1, 3 and 4 (each within the scatter of the next).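

In this assay, among the compounds shown here, the swap of 5-nitrothiophen-3-yl for 2,6-dimethoxyphenyl gives the first single-change comparison in this set, with a 10-fold higher number from compound 2 to compound 4 (1.00 log units; beyond the scatter). The rest of compound 2 stays the same, so this one group, on a double-bonded chain carbon bound to a double-bonded chain carbon, clearly matters for growth inhibition, and the change weakens it beyond the usual scatter. Nothing measured here explains why the step is this large.

A single pair cannot show whether the result follows from losing the nitro group, losing the thiophene ring, or adding the two methoxy groups. A plain phenyl or an unsubstituted thiophen-3-yl at the same place would help separate these three changes.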